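From Cyclohexyl to 3-Methylphenyl on a Shared Core

The source may hold more compounds than are shown below. What is called first, only, known or untested is meant among the compounds shown, and "the series" means these compounds.

Three compounds with the same core have been measured:

compound 1, `Fc1cc(Nc2nc3nonc3nc2Nc2ccc(C(F)(F)F)c(F)c2)ccc1C(F)(F)F`, 1700 nM
compound 2, `C1CCC(Nc2nc3nonc3nc2NC2CCCC2)C1`, 45000 nM
compound 3, `Fc1ccccc1Nc1nc2nonc2nc1NC1CCCCC1`, 13400 nM

These values come from an assay on mitochondria from L6 cells (Rattus norvegicus) for activation, with a stated time of 90 min; on this read-out lower numbers stand for an effect already at smaller amounts and higher numbers for an effect only at larger amounts of compound. Compound 3 stands second highest of the three numbers. Its nearest neighbour is compound 2, whose number is higher by more than the scatter; compound 1 lies furthest away, with a number lower by well beyond the scatter. Among these three, compound 1 carries an aromatic ring on each of the two nitrogens, compound 2 a non-aromatic ring on each, and compound 3 one of each, and the numbers fall in that order.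

Compound 4, `Cc1cccc(Nc2nc3nonc3nc2Nc2ccccc2F)c1`, has not been measured. It differs from compound 3 in one place: 3-methylphenyl in place of cyclohexyl on a nitrogen on an aromatic ring. With this change, compound 4 comes to carry an aromatic ring on both nitrogens, as compound 1 does. In this assay a step towards a lower number is therefore expected, of a size beyond the scatter, though compound 4 lacks the groups that compound 1 carries on its rings. The expected step is a 3.4-fold lower number from compound 3 to compound 4 (0.53 log units; beyond the scatter). For compound 4 the estimate in this assay is 4000 nM, within a range from 1500 nM to 12000 nM.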

Compound 4, half-maximal effective concentration: 1500 nM
Compound 4: the middle estimate sits 2.7-fold (0.43 log units) above what was measured; measured number inside the range.
By their numbers in this assay, from the lowest: compounds 4 and 1 (each within the scatter of the next); then compound 3; then compound 2.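

Until now, every pair of compounds differed in more than one place, so no change in number could be tied to a single group. Here, with the rest of the molecule held the same, 3-methylphenyl in place of cyclohexyl on a nitrogen on an aromatic ring gives an 8.9-fold lower number from compound 3 to compound 4 (0.95 log units; beyond the scatter) in this assay, showing that the number responds to what sits at this position. Nothing measured here explains why the number moves in this way.

This one step replaces a non-aromatic ring with an aromatic one and adds a methyl group at the same time, so it cannot separate the two changes; plain phenyl at this position would tell them apart. Also open, from the compounds shown here alone, is how the number would respond to 4-methylphenyl, to a ring carrying an amine or a carboxylic acid, or to a longer open carbon chain in place of the ring.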